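The source may report more compounds than this note shows. Statements on the series, on what has been measured and on what is new or still open speak of the compounds shown alone.

Measured in an ADME assay on Vero 76 cells (Chlorocebus sabaeus) for cytotoxicity, read by MTT assay, with a stated time of 96 h; on this read-out higher numbers stand for lower toxicity in this test and lower numbers for higher toxicity in this test:
- compound 1 `NS(=O)(=O)c1ccc(N2N=C(c3ccccc3)CC2c2ccccc2F)cc1`: 28000 nM
- compound 2 `NS(=O)(=O)c1ccc(N2N=C(c3ccc(Oc4ccccc4)cc3)CC2c2ccccc2)cc1`: 85000 nM
- compound 3 `NS(=O)(=O)c1ccc(N2N=C(c3ccc(OCc4ccccc4)cc3)CC2c2ccccc2F)cc1`: > 100000 nM (a limit of the assay)

Compound 1, at 28000 nM, holds the lower of the two exact numbers, and compound 2 gives 85000 nM. Compound 4 `Cc1ccccc1C1CC(c2ccccc2)=NN1c1ccc(S(N)(=O)=O)cc1` has methyl in place of fluoro on an aromatic carbon, ortho to a large group (methyl in place of fluoro on an aromatic carbon). Going by the values given here, the only measured step, an at least 3.5-fold higher number from compound 1 to compound 3 (0.55 log units; beyond the scatter), puts benzyloxy in place of hydrogen on an aromatic carbon. It rests on the limit of > 100000 nM in this assay, at which 1 of the 3 values shown sits, and does not test this exchange. No step beyond the scatter is therefore expected in this assay, and the estimated change is a 1.3-fold higher number from compound 1 to compound 4 (0.10 log units; within the scatter). For compound 4 the estimated value is 35000 nM, with an expected range from 15000 nM to 80000 nM.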

Compound 4, half-maximal cytotoxic concentration: 24000 nM
Estimate against measurement, compound 4: 1.5-fold (0.16 log units) above; low and high end bracket the measured number.
By their numbers in this assay, from the lowest: compounds 4 and 1 (each within the scatter of the next); then compound 2. At a limit, above all of these: compound 3.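

In this assay, the exchange of 2-fluorophenyl to 2-methylphenyl gives a 1.2-fold lower number from compound 1 to compound 4 (0.07 log units; within the scatter), so methyl in place of fluoro at this position, ortho to a large group, moves the number by no more than the scatter. Going by these compounds alone, the earlier step concerned benzyloxy at another place, so this is the first reading of this position. Nothing shown explains this result.

As far as these compounds go, it remains open whether an amine, a hydroxyl or a carboxylic acid at this position would also stay within the scatter. From the compounds shown here alone, it is equally open whether a longer chain there would do so.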